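A few compounds are considered here, and "the series" means these few. Any claim that something is new, unique, unknown or untested is made for them only; others in the source may bear on it.

Going by the values given here, compound 2, `CCOc1ccc(Cl)c(-c2ccc(OCCCC(=O)O)cc2)c1`, is the compound with the lower of the two numbers so far. In a functional assay on isolated protein for agonist activity at Free fatty acid receptor 1 (Homo sapiens), read by HTRF and inositol phosphate accumulation, with a stated time of 60 min (a lower number here means that less compound is needed, a higher number that more compound is needed for the effect), compound 2 gives 1130 nM. Its only measured neighbour, compound 1, `O=C(O)CCCOc1ccc(-c2cccc(Oc3ccccc3)c2)cc1`, gives in this assay 6800 nM, a gap that lies beyond the usual scatter, so compound 2 stands clearly ahead of compound 1 on the numbers shown. Compound 3, `CCOc1ccc(F)c(-c2ccc(OCCCC(=O)O)cc2)c1`, has not yet been measured; it differs from compound 2 by fluoro in place of chloro on an aromatic carbon. Among the compounds with values here, no measured pair shows this particular change, so there is no step to lean on, and the expectation rests on the size of the change alone: a single halogen exchanged for another on the same aromatic carbon. The step from compound 2 to compound 3 in this assay is estimated as a 1.6-fold higher number from compound 2 to compound 3 (0.20 log units; within the scatter), a modest rise that may not clear the scatter. For compound 3 the expected value is 1800 nM, within 700 nM to 4500 nM.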

Compound 3, half-maximal effective concentration: 3190 nM
For compound 3 the middle estimate is 1.8-fold (0.25 log units) below the measured one, and the stated range covers the measured number.
By their numbers in this assay, from the lowest: compound 2; then compound 3; then compound 1.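

In this assay, going by these compounds alone, the exchange of fluoro for chloro on this aromatic carbon, ortho to a large group and para to an ethoxy group, gives a 2.8-fold higher number from compound 2 to compound 3 (0.45 log units; beyond the scatter) and is the first single change that can be read. The position therefore distinguishes between these two halogens, although each is a single heavy atom, and chloro holds the lower number. Nothing available explains this difference.

The compounds shown leave open whether bromo, methyl or a plain hydrogen on the same aromatic carbon would stand nearer to chloro or to fluoro. Equally open, going by these compounds, is what a methoxy group or a longer chain in place of the ethoxy group would do with chloro kept in place.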